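The compounds below may be only part of what the source reports. "The series", "measured", "known", "first", "only" and "open" are said of these compounds alone.

Measured in a functional assay on HepG2 cells (Homo sapiens) for inhibition, read by MTT assay, with a stated time of 72 h; a higher number here means a weaker inhibitor, a lower number a stronger inhibitor:
- compound 1 `CC(C)(C)n1cc2c(n1)C(=O)CC1(CCN(C(=O)c3cc(-c4ccc(Cl)cc4)nc4ccccc34)CC1)O2`: 630 nM
- compound 2 `CC(C)(C)n1cc2c(n1)C(=O)CC1(CCN(C(=O)c3cc(-c4ccc(N)cc4)nc4ccccc34)CC1)O2`: 630 nM
- compound 3 `COc1cc(C(=O)N2CCC3(CC2)CC(=O)c2nn(C(C)(C)C)cc2O3)c2ccccc2n1`: > 10000 nM, a limit and not a number

Compound 3 sits at the limit of > 10000 nM in this assay, at which 1 of the 3 values shown sits. Compound 4 `CCOc1cc(C(=O)N2CCC3(CC2)CC(=O)c2nn(C(C)(C)C)cc2O3)c2ccccc2n1` differs from it by methyl in place of hydrogen on a saturated chain carbon bound to an oxygen on an aromatic ring, which turns methoxy into ethoxy. For the measured compounds named here, no measured step changes this chain directly. The nearest evidence is methoxy in place of 4-chlorophenyl, which gave an at least 15-fold higher number from compound 1 to compound 3 (1.20 log units; beyond the scatter), and methoxy in place of 4-aminophenyl, which gave an at least 15-fold higher number from compound 2 to compound 3 (1.20 log units; beyond the scatter). Both steps are large, and compound 4, like compound 3, carries neither phenyl group. The expected change is small, with the estimate being a number no higher from compound 3 to compound 4 (the limit leaves the size open), so no step beyond the scatter is expected. For compound 4 the estimated value is 10000 nM, with an expected range of 3000 nM to 20000 nM.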

Compound 4, half-maximal inhibitory concentration: > 10000 nM
Compound 4 gave a limit, no number; the forecaster's own chance of this, stated with the estimate: 70%; the middle value sits exactly at the limit.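

In this assay, compound 4 with ethoxy gives a limit and not a number, as compound 3 with methoxy does: the limit of > 10000 nM in this assay, at which 2 of the 4 values shown sit.

So the large loss seen with methoxy also appears with ethoxy, in an at least 15-fold higher number from compound 2 to compound 4 (1.20 log units; beyond the scatter) and in an at least 15-fold higher number from compound 1 to compound 4 (1.20 log units; beyond the scatter). The step between the two alkoxy compounds, compound 3 and compound 4, cannot be read, as both values are limits.

Still open, as far as these compounds go, is whether a phenyl group without chloro or amino, or a longer chain such as butoxy, would give a readable number in this assay.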